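A few compounds are considered here, and "the series" means these few. Any claim that something is new, unique, unknown or untested is made for them only; others in the source may bear on it.

In a functional assay (strain AB) with Danio rerio as the target, read by microscopy, with a stated time of 1 h (a higher number here means that more compound is needed for the effect, a lower number that less compound is needed), compound 1 `CCN1CCc2c(sc(NC=O)c2C(N)=O)C1` gives > 25000 nM, which is a limit and not a number. Compound 2 `CCN1CCc2c(sc(NC(=O)NCC3CCCO3)c2C(N)=O)C1` gives > 25000 nM, which is also a limit. Compound 2 therefore stands with compound 1 at the limit of > 25000 nM in this assay, at which 2 of the 3 values shown sit, and no number places it. Among the measured compounds shown here, the one measured step, a step that the two limits leave unreadable from compound 1 to compound 2, has no readable size and so gives no guide to the next change.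

Compound 4 `CCN1CCc2c(sc(NC(=O)Nc3cccc(C#N)c3)c2C(N)=O)C1` keeps the core of compound 2 and exchanges one group: 3-cyanophenyl in place of (oxolan-2-yl)methyl on an amide-type nitrogen. A 3-cyanophenyl thus replaces (oxolan-2-yl)methyl on an amide-type nitrogen. For the measured compounds named here, the only number comes from compound 3 `CCN1CCc2sc(NC(=O)Nc3ccc(Cl)cc3)c(C(N)=O)c2CC1`, which gives 5800 nM in this assay. Going by the values given here, compound 3 also has a six-membered aromatic ring of carbon only on an amide-type nitrogen, but it does not share the core of compound 2, so it offers a point of reference and no measured step.

On the strength of that value of compound 3 at 5800 nM, a move toward less compound needed is expected in this assay. A further limit remains possible for compound 4. The estimated size of the change is an at least 2.7-fold lower number from compound 2 to compound 4 (0.44 log units; beyond the scatter). For compound 4 the expected value is 9000 nM, with an estimated range from 3000 nM to 25000 nM.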

Compound 4, half-maximal effective concentration: 10300 nM
Estimate against measurement, compound 4: 1.1-fold (0.06 log units) below; the measured number falls inside the stated range.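

In this assay, among the compounds shown here, the exchange on this amide-type nitrogen gives the first readable step: an at least 2.4-fold lower number from compound 2 to compound 4 (0.38 log units; beyond the scatter). For the compounds shown here, it shows that a change at this one place, with 3-cyanophenyl in place of (oxolan-2-yl)methyl on the shared core, is enough to bring compound 4 to a measured number, 10300 nM, where the earlier steps on this core offered no readable size. The true size of the step may be larger, because compound 2 carries only a limit and not a number: the limit of > 25000 nM in this assay, at which 2 of the 4 values shown sit.

The compounds shown do not separate the share of the six-membered aromatic ring from that of the nitrile in this step, and a plain phenyl on the same nitrogen would speak directly to that question. They also leave open how a carboxylic acid or an amine on that ring, or a benzyl group on this nitrogen, would read in this assay.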